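Dropping the Methyl from Compound 3

The source may report more compounds than this note shows. Statements on the series, on what has been measured and on what is new or still open speak of the compounds shown alone.

compound 1 `COc1ccc2ncc(S(=O)(=O)c3ccc(OC)c(Cl)c3)c(N3CCC(C)CC3)c2c1`: 21%
compound 2 `Cc1ccc2ncc(S(=O)(=O)c3cccc(Cl)c3)c(N3CCC(C)CC3)c2c1`: 91%
compound 3 `COc1ccc2ncc(S(=O)(=O)c3ccc(C)c(Cl)c3)c(N3CCC(C)CC3)c2c1`: 85%

In an assay on isolated protein for displacement of a labelled ligand from metabotropic glutamate receptor 5 (Homo sapiens), with a stated time of 60 min, tested at 1 uM (on this read-out higher numbers stand for more inhibition at the one concentration tested (going by the name of the read-out) and lower numbers for less inhibition), compound 3 gives 85%, the second highest of the three numbers; compound 2 gives 91%, within the scatter of it, while compound 1 gives 21%, far lower. Among the compounds with values here, the one single-place step known here, a number 64 percentage points higher from compound 1 to compound 3 (beyond the scatter), shows methyl in place of methoxy on an aromatic carbon lifting inhibition strongly. Compound 4 `COc1ccc2ncc(S(=O)(=O)c3cccc(Cl)c3)c(N3CCC(C)CC3)c2c1` differs from compound 3 by hydrogen in place of methyl on an aromatic carbon. Within the data shown here, no measured step removes a methyl outright, so that step bears only loosely. Compound 2 carries the same 3-chlorophenyl group on a different core and gives 91%, which points toward little loss. Compound 4 is therefore expected near 80%, between 60% and 95%. That expected step, a number 5 percentage points lower from compound 3 to compound 4 (within the scatter), likely stays within the scatter.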

Compound 4, a percentage reported as inhibition, at one concentration (the size of the read-out at that concentration, not a potency): -3%
Estimate against measurement, compound 4: 83 percentage points above; the whole stated range lies above it.
By their numbers in this assay, from the lowest: compound 4; then compound 1; then compounds 3 and 2 (each within the scatter of the next).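

In this assay, the methyl para to the large group carries nearly all the inhibition of compound 3: hydrogen in its place gives a number 88 percentage points lower from compound 3 to compound 4 (beyond the scatter), and hydrogen in place of methoxy at that carbon gives a number 24 percentage points lower from compound 1 to compound 4 (beyond the scatter), so methoxy retains a little and hydrogen less. With the 3-chlorophenyl group kept, methoxy in place of methyl on the core gives a number 94 percentage points lower from compound 2 to compound 4 (beyond the scatter), so a single methyl at either place is enough here. The size of the swap depends on where it is made: the same change on two cores in this assay, a number 64 percentage points higher (beyond the scatter) from compound 1 to compound 3 and a number 94 percentage points higher (beyond the scatter) from compound 4 to compound 2, 30 percentage points apart, beyond the scatter of two such steps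

As far as these compounds go, whether an ethyl group or an amine on that aromatic carbon would keep the inhibition remains open.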